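The source may hold more compounds than are shown below. What is called first, only, known or untested is meant among the compounds shown, and "the series" means these compounds.

In a functional assay on SK-BR-3 cells (Homo sapiens) for antiproliferative activity (a higher number here means a weaker inhibitor, a lower number a stronger inhibitor), three compounds have been measured:
compound 1, `CC(C)=CCc1cc(C(=O)Nc2cc3ccc(OCC4CCCN(C)C4)c(C)c3oc2=O)ccc1O`, gives 1300 nM
compound 2, `CC(C)=CCc1cc(C(=O)Nc2cc3ccc(OCC4CCCNC4)c(C)c3oc2=O)ccc1O`, gives 600 nM
compound 3, `CCCN(CCC)CCCOc1ccc2cc(NC(=O)c3ccc(O)c(CC=C(C)C)c3)c(=O)oc2c1C`, gives only a limit of the assay, > 50000 nM

Among the two numbers, compound 1 stands highest; its nearest neighbour is compound 2, with a 2.2-fold lower number from compound 1 to compound 2 (0.34 log units; beyond the scatter). Compound 3 sits at the limit of > 50000 nM in this assay, at which 1 of the 3 values shown sits. Compound 4, `CC(C)=CCc1cc(C(=O)Nc2cc3ccc(OCCCN(C)C(C)C)c(C)c3oc2=O)ccc1O`, differs from compound 1 in one place: 2-(isopropyl(methyl)amino)ethyl in place of 1-methylpiperidin-3-yl on a saturated chain carbon bound to an oxygen on an aromatic ring. Going by the values given here, two measured steps bear on this change, both replacing the ring with an open chain on the same carbon: an at least 38-fold higher number from compound 1 to compound 3 (1.58 log units; beyond the scatter) and an at least 83-fold higher number from compound 2 to compound 3 (1.92 log units; beyond the scatter), both large rises. A large rise is therefore expected for compound 4 in this assay, estimated at 15000 nM with a range of 4000 nM to 60000 nM, meaning an expected 12-fold higher number from compound 1 to compound 4 (1.06 log units; beyond the scatter).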

Compound 4, half-maximal inhibitory concentration: 570 nM
The estimate for compound 4 lay 26-fold (1.42 log units) above the measured number; measured number below the stated range.
By their numbers in this assay, from the lowest: compounds 4 and 2 (each within the scatter of the next); then compound 1. At a limit, above all of these: compound 3.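

In this assay, replacing the ring with an open chain does not by itself cost activity at this position: a 2.3-fold lower number from compound 1 to compound 4 (0.36 log units; beyond the scatter), and a 1.1-fold lower number from compound 2 to compound 4 (0.02 log units; within the scatter). With the chain held the same, the large change follows the amine, isopropyl(methyl)amino in place of dipropylamino: an at least 87-fold lower number from compound 3 to compound 4 (1.94 log units; beyond the scatter). For compound 3 the value is a limit of the assay, not a number: the limit of > 50000 nM in this assay, at which 1 of the 4 values shown sits.

The compounds shown leave open how a dimethylamino or pyrrolidine group would behave at the end of this chain. They also leave open whether a shorter chain would keep the value of compound 4.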